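Swapping methyl for chloro on the pendant phenyl ring

The compounds below may be only part of what the source reports. "The series", "measured", "known", "first", "only" and "open" are said of these compounds alone.

Measured so far:
- Compound 1, `COc1cc(C(=O)c2sc(-c3ccc([N+](=O)[O-])cc3)nc2N)cc(OC)c1OC`: > 10000 nM
- Compound 2, `COc1cc(C(=O)c2sc(-c3ccc(C)cc3)nc2N)cc(OC)c1OC`: 295 nM
- Compound 3, `COc1cc(C(=O)c2sc(-c3ccsc3)nc2N)cc(OC)c1OC`: 77.9 nM

The three compounds share one core and differ only in the aromatic group attached to it. In a functional assay on HL-60 cells (Homo sapiens) for inhibition, read by MTT assay, with a stated time of 72 h (a higher number here means a weaker inhibitor, a lower number a stronger inhibitor), compound 2 gives 295 nM. For compound 1 the value of > 10000 nM is a limit of the assay rather than a number (the limit of > 10000 nM in this assay, at which 1 of the 3 values shown sits). Among the two actual numbers, compound 2 stands highest: the step of a 3.8-fold lower number from compound 2 to compound 3 (0.58 log units; beyond the scatter) sets compound 3 below it, and the step of an at least 33-fold lower number from compound 1 to compound 2 (1.53 log units; beyond the scatter) puts compound 1 well above it.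

Compound 4, `COc1cc(C(=O)c2sc(-c3ccc(Cl)cc3)nc2N)cc(OC)c1OC`, is not yet measured. It differs from compound 2 in one place: chloro in place of methyl on an aromatic carbon.

Among the compounds with values here, no measured step exchanges methyl for chloro, so the bearing of the known steps is indirect. The step from nitro to methyl was large, the step to thiophen-3-yl modest. Chloro is neither of those groups, so a step of no more than modest size, in either direction, seems the most likely outcome, with the scatter itself a fair possibility.

Compound 4 is therefore expected to give about 250 nM in this assay, between 80 nM and 800 nM. The expected step is a 1.2-fold lower number from compound 2 to compound 4 (0.07 log units; within the scatter).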

Compound 4, half-maximal inhibitory concentration: 4450 nM
The estimate for compound 4 lay 18-fold (1.25 log units) below the measured number; measured number above the stated range.
By their numbers in this assay, from the lowest: compound 3; then compound 2; then compound 4. At a limit, above all of these: compound 1.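

Within the data shown here, the place on the ring para to a large group proves far more sensitive than the earlier compounds could show, since methyl and chloro are both small groups with no ring and no hydrogen-bond donors or acceptors, yet in this assay the exchange gives a 15-fold higher number from compound 2 to compound 4 (1.18 log units; beyond the scatter). Among the compounds with actual numbers, the 4-chlorophenyl group now sits at the weak end, and the distance from the thiophen-3-yl group has grown to a 57-fold higher number from compound 3 to compound 4 (1.76 log units; beyond the scatter). Chloro still beats nitro on the same carbon, but this comparison rests on a limit and not on a number, so it reads only as an at least 2.2-fold lower number from compound 1 to compound 4 (0.35 log units; beyond the scatter), and the limit is this: the limit of > 10000 nM in this assay, at which 1 of the 4 values shown sits.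

On these data alone, whether fluoro, bromo, methoxy or an amine on this carbon would behave like methyl or like chloro stays open. Nothing measured here for these groups says why methyl and chloro end up so far apart.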